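This account rests on a few compounds, and the source may have more. Where it says the series, first, only, none or still open, it means among the compounds named here.

Two compounds share a core and differ only in the aromatic group attached to it. Among the measured compounds shown here, in an assay (Rattus norvegicus) for inhibition of Fatty-acid amide hydrolase 1 (Homo sapiens) (on this read-out higher numbers stand for weaker inhibition and lower numbers for stronger inhibition), compound 1 `COc1ccccc1-c1cnc(C(=O)CCCCCCc2ccccc2)o1` gives 400 nM, the highest of the two numbers measured so far. Compound 2 `COC(=O)c1ccc(-c2cnc(C(=O)CCCCCCc3ccccc3)o2)cc1` gives 40 nM in this assay, a number that lies beyond the usual scatter from that of compound 1. Compound 3 `N#Cc1ccc(-c2cnc(C(=O)CCCCCCc3ccccc3)o2)cc1` has not yet been measured. It differs from compound 1 in one place: 4-cyanophenyl in place of 2-methoxyphenyl on an aromatic carbon. For the measured compounds named here, no pair of measured compounds shows this exact change, so its size can only be estimated. Because compound 2 carries a different group on the same core and reaches 40 nM, a move toward stronger inhibition seems more likely than a move the other way. The step expected here is a 6.7-fold lower number from compound 1 to compound 3 (0.82 log units; beyond the scatter). Compound 3 is therefore estimated at 60 nM, with a likely range from 20 nM to 200 nM.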

Compound 3, inhibition constant: 40 nM
Estimate against measurement, compound 3: 1.5-fold (0.18 log units) above, within the range that was stated.
By their numbers in this assay, from the lowest: compounds 2 and 3 (each within the scatter of the next); then compound 1.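

In this assay the swap of 2-methoxyphenyl for 4-cyanophenyl gives a 10-fold lower number from compound 1 to compound 3 (1.00 log units; beyond the scatter) and so shows that the stronger inhibition seen with compound 2 is not tied to a single group on the shared core. Cyano in place of methoxycarbonyl gives no change at the digits printed from compound 2 to compound 3 (within the scatter) and so leaves these two groups indistinguishable on this read-out. Nothing available here offers a reason for either result.

The change from compound 1 to compound 3 alters both the group on the aromatic ring and where it sits, so the compounds shown cannot separate these two effects, which a 4-methoxyphenyl group could begin to do. Also open, as far as these compounds go, is how a plain phenyl group, or a phenyl group carrying a carboxylic acid or an amine, would compare.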